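The source may hold more compounds than are shown below. What is called first, only, known or untested is meant among the compounds shown, and "the series" means these compounds.

Compound 3 `CNc1nc(N)c2sc(-c3ccc(C(F)(F)F)cc3)cc2n1` is known in a physicochemical assay for solubility, at pH 2 (a higher number here means a more soluble compound, a lower number a less soluble compound), only as a limit, > 100 ug/mL. Compound 1 `CNc1nc(OCCCN(C)C)c2sc(-c3ccc(C(F)(F)F)cc3)cc2n1` gives 174 ug/mL in this assay, and compound 2 `CNc1nc(NCCN2CCNCC2)c2sc(-c3ccc(C(F)(F)F)cc3)cc2n1` gives 203 ug/mL; the step of a 1.2-fold higher number from compound 1 to compound 2 (0.07 log units; within the scatter) separates them. The steps a step that the limit leaves unreadable from compound 1 to compound 3 and a step that the limit leaves unreadable from compound 2 to compound 3 cannot be sized because of the limit of > 100 ug/mL in this assay, at which 1 of the 3 values shown sits. Compound 4 `CNc1nc(NC(C)(C)C)c2sc(-c3ccc(C(F)(F)F)cc3)cc2n1` differs from compound 3 by tert-butyl in place of hydrogen on a nitrogen on an aromatic ring. Within the data shown here, no measured step covers this change, and the one readable step, a 1.2-fold higher number from compound 1 to compound 2 (0.07 log units; within the scatter), concerns a different position. The step of an at least 1.2-fold lower number from compound 3 to compound 4 (0.09 log units; that floor lies within the scatter) is therefore estimated with wide uncertainty, and it may amount to nothing beyond the scatter. Compound 4 is expected to give about 80 ug/mL in this assay, within a range from 20 ug/mL to 250 ug/mL.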

Compound 4, solubility: 1.6 ug/mL
Compound 4: the middle estimate sits 50-fold (1.70 log units) above what was measured; the whole stated range lies above it.
By their numbers in this assay, from the lowest: compound 4; then compounds 1 and 2 (each within the scatter of the next).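

In this assay, among these compounds, the group at this position now makes a difference beyond the scatter, which the earlier compounds did not show: a 130-fold lower number from compound 2 to compound 4 (2.10 log units; beyond the scatter), and a 110-fold lower number from compound 1 to compound 4 (2.04 log units; beyond the scatter). The value of compound 3 is only a limit, so the steps from compounds 1 and 2 to compound 3 still cannot be read. For the same reason, an at least 62-fold lower number from compound 3 to compound 4 (1.79 log units; beyond the scatter) gives only a floor: the limit of > 100 ug/mL in this assay, at which 1 of the 4 values shown sits.

As far as these compounds go, it remains open how an ethyl or isopropyl group on this nitrogen would compare with tert-butyl. Also open, from the compounds shown here alone, is where a chain ending in a carboxylic acid would fall.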